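The compounds below may be only part of what the source reports. "The series", "measured", "known", "first", "only" and "open" are said of these compounds alone.

Measured compounds:
Compound 1 `CCOC(=O)C1(Cc2ccccc2)CN(c2ccccc2)Cc2nnn(Cc3cc(OC)c(OC)c(OC)c3)c21` gives >= 100000 nM in an ADME assay on HEL cells (Homo sapiens) for cytotoxicity, read by microscopy, with a stated time of 3 days; a higher number here means that more compound is tolerated, a lower number that less compound is tolerated.
Compound 2 `CCOC(=O)C1(Cc2ccccc2)CN(c2ccccc2)Cc2nnn(Cc3ccc(OC)cc3)c21` gives > 100000 nM in this assay.
Compound 3 `CCOC(=O)C1(Cc2ccccc2)CN(c2ccccc2)Cc2nnn(Cc3cccc(Cl)c3)c21` gives > 100000 nM in this assay.

Compound 3 stands at a limit of this assay, not at a measured number. The same holds for the other two: there is the limit of > 100000 nM in this assay, at which 2 of the 3 values shown sit, and (the limit of >= 100000 nM in this assay, at which 1 of the 3 values shown sits), so none of the three compounds gave a number below the top of the tested range. As a consequence, every step between them is unreadable: a step that the two limits leave unreadable from compound 1 to compound 2, a step that the two limits leave unreadable from compound 1 to compound 3 and a step that the two limits leave unreadable from compound 2 to compound 3 cannot be sized, since each joins two limits.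

Compound 4 `CCOC(=O)C1(Cc2ccccc2)CN(c2ccccc2)Cc2nnn(Cc3ccc(Cl)cc3)c21` differs from compound 3 by a single change: 4-chlorophenyl in place of 3-chlorophenyl on a saturated chain carbon bound to an aromatic nitrogen. Going by the values given here, the steps that bear on this change are those that already swapped the group on that same saturated chain carbon, namely from compound 1 and compound 2 to compound 3, and both were left unreadable by their limits. No readable step therefore exists on which to expect a direction, and nothing among the three compounds moved away from the limit when that group was varied.

Compound 4 is expected to behave the same way, with an estimated 100000 nM and a range of 50000 nM to 200000 nM, most likely reported again as a limit. The expected step is a number no higher from compound 3 to compound 4 (the limit leaves the size open), within the scatter.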

Compound 4, minimum cytotoxic concentration: > 100000 nM
Compound 4: a limit, no number (the forecaster's own chance of this, stated with the estimate: 90%); the middle value lies on the limit itself.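

Going by these compounds alone, compound 4 gives a limit rather than a number in this assay, as do compound 1, compound 2 and compound 3, so no step from any of them to compound 4 can be read. The compounds shown leave open at what concentration any of them becomes cytotoxic, and whether the group on the saturated chain carbon affects that concentration.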